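Adding a Phenyl to Compound 2: Expected Cytotoxicity

The source may hold more compounds than are shown below. What is called first, only, known or untested is meant among the compounds shown, and "the series" means these compounds.

Compound 1 `NC(=S)Nc1cccc(OCCCCCCCc2ccccc2)c1`: 23000 nM
Compound 2 `NC(=S)Nc1cccc(OCCCCCOc2ccccc2)c1`: > 50000 nM (a limit)
Compound 3 `NC(=S)Nc1cccc(OCCCCCOc2ccc(C(=O)O)cc2)c1`: > 50000 nM (a limit)

In an ADME assay on Ava5 cells (Homo sapiens) for cytotoxicity (a lower number here means that less compound is tolerated, a higher number that more compound is tolerated), compound 2 gives > 50000 nM, which is a limit of the assay rather than a number. Compound 3 likewise sits at a limit, > 50000 nM. Two of the three values share this limit (the limit of > 50000 nM in this assay, at which 2 of the 3 values shown sit). Compound 4 `NC(=S)Nc1cccc(OCCCCCOc2cccc(-c3ccccc3)c2)c1` differs from compound 2 by phenyl in place of hydrogen on an aromatic carbon. Among the compounds with values here, two steps bear on this: an at least 2.1-fold higher number from compound 1 to compound 2 (0.33 log units; beyond the scatter) and a step that the two limits leave unreadable from compound 2 to compound 3. Since compound 2 itself is only a limit, the step of an at least 1.2-fold lower number from compound 2 to compound 4 (0.09 log units; that floor lies within the scatter) is estimated as small, within the scatter, with some chance of a lower number. Compound 4 is therefore expected near 40000 nM, in a range from 15000 nM to 100000 nM.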

Compound 4, half-maximal cytotoxic concentration: 13000 nM
Estimate against measurement, compound 4: 3.1-fold (0.49 log units) above; the measured number lies below the stated range.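

In this assay, phenyl in place of hydrogen on an aromatic carbon, meta to a large group, gives an at least 3.8-fold lower number from compound 2 to compound 4 (0.58 log units; beyond the scatter). This is a step beyond the scatter on that aromatic ring, whereas the carboxy change in compound 3 left a step that cannot be read. Only the lower bound of the new step is known, since compound 2 gives > 50000 nM, a limit of the assay: the limit of > 50000 nM in this assay, at which 2 of the 4 values shown sit.

Going by these compounds, whether a smaller group such as methyl or chlorine would lower the number at this position stays open. So does the effect of an amine or a carboxylic acid on the added phenyl.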